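The compounds below may be only part of what the source reports. "The series", "measured", "known", "first", "only" and "open" are said of these compounds alone.

The study gathers sesquiterpenoid-type compounds and follows them in a functional assay on HCT-8 cells (Homo sapiens) for cytotoxicity, read by MTT assay; a lower number here means a stronger inhibitor, a higher number a weaker inhibitor. Compound 1 `C/C1=C/C2=C(CC(C)(C)C2=O)[C@H](C)CC[C@@H]1O` carries a bicyclic framework with a secondary alcohol on the larger ring. In this assay compound 1 gives > 10 ug/mL, which is a limit of the assay rather than a number. Compound 2 `CC(=O)CC/C=C(/C)CC1=CC(C)(C)CC1=O` opens that framework into a chain ending in an acetyl group. In this assay compound 2 also gives > 10 ug/mL, again a limit and not a number. Going by the values given here, compound 2 therefore stands where everything measured so far stands: the limit of > 10 ug/mL in this assay, at which 2 of the 2 values shown sit, so no step between measured compounds can be sized, and no ordering of the two can be read from the numbers.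

Compound 3 `C/C(=C/CC[C@H](C)O)CC1=CC(C)(C)CC1=O` differs from compound 2 in a single place: 1-hydroxyethyl in place of acetyl on a saturated chain carbon, two bonds along the chain from a double-bonded chain carbon. The acetyl leaves and a 1-hydroxyethyl enters, bringing one hydrogen-bond donor and one defined stereocentre. With both measured compounds at the limit, the study has nothing on which to base an expectation of a step beyond the usual scatter, in either direction. Compound 3 is therefore expected to remain close to where compound 2 sits, with a step that the limit leaves unreadable from compound 2 to compound 3 meaning essentially no change. The estimate for compound 3 in this assay is 12 ug/mL, with a range from 5 ug/mL to 30 ug/mL, and most likely the assay again reports only a limit.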

Compound 3, half-maximal inhibitory concentration: > 10 ug/mL
Compound 3 ended at the assay's limit; the forecaster's own chance of this, stated with the estimate: 70%; the middle value does not contradict the limit.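

The change from acetyl to 1-hydroxyethyl gives no readable step between compound 2 and compound 3 in this assay, as each result is a limit and not a number: the limit of > 10 ug/mL in this assay, at which 3 of the 3 values shown sit.

The compounds shown leave open whether any of them differs from the others in this assay, and which change, if any, would bring a measurable value.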